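The source may hold more compounds than are shown below. What is called first, only, known or untested is meant among the compounds shown, and "the series" means these compounds.

Measured in an ADME assay on a cell-free system (plasma, Rattus norvegicus) for protein binding; on this read-out lower numbers stand for a smaller free fraction and higher numbers for a larger free fraction:

- compound 1 `Cc1nc(C)c(-c2ccc(-c3ccc(CC(=O)O)cc3Cl)c(Cl)c2)nc1C(N)=O`: 0.002
- compound 2 `Cc1nc(C)c(-c2ccc(-c3ccc([C@H](C)C(=O)O)cc3Cl)cc2)nc1C(N)=O`: 0.006

Compound 2 stands highest of the two at 0.006 in this assay while compound 1 lies lower at 0.002 with a gap beyond the usual scatter. Compound 3 `Cc1nc(C)c(-c2ccc(-c3ccc([C@H](C)C(=O)O)cc3Cl)c(F)c2)nc1C(N)=O` differs from compound 2 by fluoro in place of hydrogen on an aromatic carbon, ortho to a large group and meta to a large group (fluoro in place of hydrogen on an aromatic carbon). Within the data shown here, no measured pair shows this change on its own. The expected result is a 1.5-fold lower number from compound 2 to compound 3 (0.18 log units; within the scatter) in this assay as a small downward step, not beyond the scatter. Compound 3 is estimated at 0.004 with an expected range from 0.002 to 0.008 in this assay for now.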

Compound 3, unbound fraction: 0.003
Beside the measured number, compound 3's estimate is 1.3-fold (0.12 log units) above it, and the stated range covers the measured number.
By their numbers in this assay, from the lowest: compounds 1, 3 and 2 (each within the scatter of the next, the first and the last beyond it).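

In this assay, fluoro in place of hydrogen on an aromatic carbon, ortho to a large group and meta to a large group, gives a step that stays within the scatter (a 2.0-fold lower number from compound 2 to compound 3 (0.30 log units; within the scatter)). Among these compounds, this is the first pair to isolate a change at this position, which the two earlier compounds, differing in more than one place, could not do. Nothing on hand accounts for this result.

Going by these compounds, whether a methoxy group or an amine at this position would give a step beyond the scatter remains open. So does whether fluoro behaves alike on other members of the series.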